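Replacing 2-fluorophenyl with 4-chlorophenyl in compound 2

The compounds below may be only part of what the source reports. "The series", "measured", "known", "first", "only" and "open" are said of these compounds alone.

Measured in a functional assay on A549 cells (Homo sapiens) for inhibition, read by colorimetric assay and MTT assay, with a stated time of 72 h; a lower number here means a stronger inhibitor, a higher number a weaker inhibitor:
- Compound 1 `C[C@]12O[C@@H]1CC[C@@]1(C)O[C@@H]1[C@H]1OC(=O)[C@@H](CN3CCN(c4ccccc4)CC3)[C@@H]1C[C@H]2O`: 48000 nM
- Compound 2 `C[C@]12O[C@@H]1CC[C@@]1(C)O[C@@H]1[C@H]1OC(=O)[C@@H](CN3CCN(c4ccccc4F)CC3)[C@@H]1C[C@H]2O`: 22000 nM

Compound 2, with 22000 nM, has the lower of the two numbers. Compound 3 `C[C@]12O[C@@H]1CC[C@@]1(C)O[C@@H]1[C@H]1OC(=O)[C@@H](CN3CCN(c4ccc(Cl)cc4)CC3)[C@@H]1C[C@H]2O` differs from it as follows: 4-chlorophenyl in place of 2-fluorophenyl on an amine nitrogen in a ring. For the measured compounds named here, only one measured step bears on this, the modest 2.2-fold lower number from compound 1 to compound 2 (0.34 log units; beyond the scatter), with fluoro in place of hydrogen on an aromatic carbon. Going by the values given here, no measured compound carries chloro, so in this assay no step beyond the scatter is expected, and the estimate is a 1.2-fold higher number from compound 2 to compound 3 (0.07 log units; within the scatter). For compound 3 the expected value is 26000 nM, with an estimated range of 10000 nM to 60000 nM.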

Compound 3, half-maximal inhibitory concentration: 28000 nM
Estimate against measurement, compound 3: 1.1-fold (0.03 log units) below; low and high end bracket the measured number.
By their numbers in this assay, from the lowest: compounds 2, 3 and 1 (each within the scatter of the next, the first and the last beyond it).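

In this assay, 4-chlorophenyl on the amine nitrogen in the ring reads the same as 2-fluorophenyl within the scatter, with a 1.3-fold higher number from compound 2 to compound 3 (0.10 log units; within the scatter). Measured against the unsubstituted phenyl, the chloro change gives a 1.7-fold lower number from compound 1 to compound 3 (0.23 log units; within the scatter), so unlike the fluoro step, it does not clear the scatter, and a halogen on this phenyl does not by itself ensure a step beyond it. Going by these compounds, the halogen and its place on the ring change together here, and how a methoxy group or a nitrile on this phenyl would read remains open. No measurement shown here accounts for these steps.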